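Dipropylamino for Piperidin-1-yl on the tert-Butyl Core

This account rests on a few compounds, and the source may have more. Where it says the series, first, only, none or still open, it means among the compounds named here.

Of the compounds shown here, three have been measured in a functional assay on HT-29 cells (Homo sapiens) for cytotoxicity, with a stated time of 4 h; a higher number here means a weaker inhibitor, a lower number a stronger inhibitor. Compound 1 `CC(C)c1ccc2c(c1)[n+]([O-])c(NCCN1CCCCC1)n[n+]2[O-]` gives 2700 nM, compound 2 `CCCN(CCC)CCNc1n[n+]([O-])c2ccc(C(C)C)cc2[n+]1[O-]` gives 4400 nM, and compound 3 `CC(C)(C)c1ccc2c(c1)[n+]([O-])c(NCCN1CCCCC1)n[n+]2[O-]` gives 4000 nM. Compound 2 arises from compound 1 by the change (dipropylamino in place of piperidin-1-yl on a saturated chain carbon, two bonds along the chain from a nitrogen on an aromatic ring), and this step made a 1.6-fold higher number from compound 1 to compound 2 (0.21 log units; within the scatter). Compound 3 arises from compound 1 by the change (methyl in place of hydrogen on a saturated chain carbon bound to an aromatic carbon and two saturated chain carbons), with a 1.5-fold higher number from compound 1 to compound 3 (0.17 log units; within the scatter). Compound 4 `CCCN(CCC)CCNc1n[n+]([O-])c2ccc(C(C)(C)C)cc2[n+]1[O-]` has not been measured; it differs from compound 3 by the change (dipropylamino in place of piperidin-1-yl on a saturated chain carbon, two bonds along the chain from a nitrogen on an aromatic ring), the same change already seen from compound 1 to compound 2, made here on the core of compound 3. The two cores differ only by the isopropyl to tert-butyl difference given above.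

Because the same change from compound 1 to compound 2 gave a 1.6-fold higher number from compound 1 to compound 2 (0.21 log units; within the scatter), the step from compound 3 to compound 4 is expected to be of a similar size, namely a 1.6-fold higher number from compound 3 to compound 4 (0.20 log units; within the scatter). In this assay compound 4 is therefore expected to give about 6300 nM, likely between 3000 nM and 13000 nM.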

Compound 4, half-maximal inhibitory concentration: 8300 nM
For compound 4 the middle estimate is 1.3-fold (0.12 log units) below the measured one, and the stated range covers the measured number.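

In this assay, dipropylamino in place of piperidin-1-yl on the core of compound 3 gave a 2.1-fold higher number from compound 3 to compound 4 (0.32 log units; beyond the scatter), and this step agrees with the one seen on the core of compound 1: the same change on two cores in this assay, a 1.6-fold higher number (0.21 log units; within the scatter) from compound 1 to compound 2 and a 2.1-fold higher number (0.32 log units; beyond the scatter) from compound 3 to compound 4, 1.3-fold (0.10 log units) apart, within the scatter of two such steps. Methyl in place of hydrogen, the second change in this set of four compounds, gave a 1.9-fold higher number from compound 2 to compound 4 (0.28 log units; within the scatter), and it too matches its earlier counterpart: the same change on two cores in this assay, a 1.5-fold higher number (0.17 log units; within the scatter) from compound 1 to compound 3 and a 1.9-fold higher number (0.28 log units; within the scatter) from compound 2 to compound 4, 1.3-fold (0.10 log units) apart, within the scatter of two such steps. Among these compounds, each change therefore carried from one core to the other without a detectable difference in size, although only the step on the core of compound 3 lies beyond the scatter, and two cores in a single assay do not show that the change would carry to any other core.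

From the compounds shown here alone, it remains open whether another amine in this place, such as morpholin-4-yl or dimethylamino, would follow the same course. Also open, going by these compounds, is what a longer chain between the two nitrogens, or a group such as methoxy in place of isopropyl or tert-butyl, would do to these steps.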